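The source may report more compounds than this note shows. Statements on the series, on what has been measured and on what is new or still open speak of the compounds shown alone.

Measured compounds:
compound 1 `c1cncc(-c2nc3ccccc3n2C2CC2)c1` — in an assay on V79 cells for inhibition of cytochrome P450 11B1, mitochondrial (Homo sapiens), read by HTRF, with a stated time of 1 h (a lower number here means a stronger inhibitor, a higher number a weaker inhibitor), compound 1 gives > 8330 nM, which is a limit of the assay and not a number.
compound 2 `Fc1ccc2nc(-c3cccnc3)n(C3CC3)c2c1` — in this assay compound 2 gives 401 nM.
compound 3 `COc1ccc2nc(-c3cccnc3)n(C3CC3)c2c1` — in this assay compound 3 gives 1980 nM.

Of the two real numbers shown, compound 3 carries the higher one; compound 2 sits at a 4.9-fold higher number from compound 2 to compound 3 (0.69 log units; beyond the scatter) from it. The unmeasured compound 4 `Clc1ccc2nc(-c3cccnc3)n(C3CC3)c2c1` differs from compound 3 in one place: chloro in place of methoxy on an aromatic carbon. Going by the values given here, two measured steps bear on this exchange. Putting fluoro onto the unsubstituted core gave an at least 20-fold lower number from compound 1 to compound 2 (1.31 log units; beyond the scatter), putting methoxy there gave an at least 4.2-fold lower number from compound 1 to compound 3 (0.62 log units; beyond the scatter), and the direct comparison of the two substituents gave a 4.9-fold higher number from compound 2 to compound 3 (0.69 log units; beyond the scatter). A halogen thus gave the lower number of the two substituents tried, and chloro is the second halogen. Compound 4 is therefore expected to move in the direction of compound 2, with a 4.0-fold lower number from compound 3 to compound 4 (0.60 log units; beyond the scatter) in this assay, a modest step beyond the scatter. The estimate for compound 4 in this assay is 500 nM, with a range from 150 nM to 2000 nM; compound 1 alone, at its limit, gives no number to anchor this further.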

Compound 4, half-maximal inhibitory concentration: 477 nM
Compound 4: the middle estimate sits 1.0-fold (0.02 log units) above what was measured, within the range that was stated.
By their numbers in this assay, from the lowest: compounds 2 and 4 (each within the scatter of the next); then compound 3. At a limit, above all of these: compound 1.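

In this assay, chloro in place of fluoro on this aromatic carbon, meta to a fused ring and para to a fused ring, gives a 1.2-fold higher number from compound 2 to compound 4 (0.08 log units; within the scatter), so the two halogens cannot be told apart here, while chloro in place of methoxy gives a 4.2-fold lower number from compound 3 to compound 4 (0.62 log units; beyond the scatter) and both halogens thus stand on the same side of methoxy. Chloro in place of hydrogen gives an at least 17-fold lower number from compound 1 to compound 4 (1.24 log units; beyond the scatter), the second large step seen with a halogen at this carbon. Compound 1 stands at a limit of the assay and not at a number: the limit of > 8330 nM in this assay, at which 1 of the 4 values shown sits.

Left open is how bromo, a nitrile or an amine would compare on this same carbon. Also open, going by these compounds, is whether the level standing of chloro and fluoro carries over to the other aromatic carbons of the shared core.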